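The source may report more compounds than this note shows. Statements on the series, on what has been measured and on what is new or still open speak of the compounds shown alone.

Compound 1 `C#CCN(C)Cc1cccc(NC(=O)CCCC(=O)NO)c1`: > 10000 nM. Compound 2 `C#CCN(C)Cc1cccc(NC(=O)CCCCCC(=O)NO)c1`: 4630 nM. Compound 3 `C#CCN(C)Cc1cccc(NC(=O)CCCCCCC(=O)NO)c1`: not yet measured.

In a functional assay on PC-3 cells (Homo sapiens) for inhibition, read by MTT assay, with a stated time of 48 h (on this read-out lower numbers stand for stronger inhibition of growth and higher numbers for weaker inhibition of growth), compound 1 reaches only a limit of the assay, > 10000 nM. Compound 1 thus sits at the limit of > 10000 nM in this assay, at which 1 of the 2 values shown sits. Compound 2 gives 4630 nM in this assay, the only number shown. For the measured compounds named here, the one measured step that bears on what follows is an at least 2.1-fold lower number from compound 1 to compound 2 (0.33 log units; beyond the scatter). Compound 3 differs from compound 2 by (hydroxycarbamoyl)methyl in place of hydroxycarbamoyl on a saturated chain carbon, five bonds along the chain from a carbonyl carbon. Since the same kind of lengthening already gave an at least 2.1-fold lower number from compound 1 to compound 2 (0.33 log units; beyond the scatter), a further modest step in that direction is expected, a 3.1-fold lower number from compound 2 to compound 3 (0.49 log units; beyond the scatter). Compound 3 is estimated at 1500 nM, between 500 nM and 5000 nM.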

Compound 3, concentration for 50% growth inhibition: 330 nM
For compound 3 the middle estimate is 4.5-fold (0.66 log units) above the measured one; measured number below the stated range.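

In this assay, (hydroxycarbamoyl)methyl in place of hydroxycarbamoyl on a saturated chain carbon, five bonds along the chain from a carbonyl carbon, gives a 14-fold lower number from compound 2 to compound 3 (1.15 log units; beyond the scatter), so this position still responds strongly to lengthening and the first real size of that response appears here. Across the shared core the number falls with each lengthening, and no compound shown goes against this. The whole change gives an at least 30-fold lower number from compound 1 to compound 3 (1.48 log units; beyond the scatter), a step that starts from a limit and not a number: the limit of > 10000 nM in this assay, at which 1 of the 3 values shown sits.

As far as these compounds go, whether a longer chain lowers the number further or raises it stays open. So does the effect of a carboxylic acid in place of the hydroxycarbamoyl end.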